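This account rests on a few compounds, and the source may have more. Where it says the series, first, only, none or still open, it means among the compounds named here.

Compound 2 `CCn1c(-c2ccccc2)nc2c(NC3CCOC3)ncnc21` gives 11500 nM in a functional assay on CHO cells for antagonist activity at adenosine receptor A2b (Homo sapiens), read by 33P incorporation, with a stated time of 20 min (on this read-out higher numbers stand for weaker inhibition and lower numbers for stronger inhibition), the higher of the two numbers measured in this series. For the measured compounds named here, its companion, compound 1 `CCn1c(-c2ccccc2)nc2c(NC3CCC3)ncnc21`, gives 1440 nM in this assay, and the single measured step, an 8.0-fold higher number from compound 1 to compound 2 (0.90 log units; beyond the scatter), shows that the group on the ring nitrogen shifts the number well beyond the scatter. Compound 3 `CCn1c(-c2ccccc2)nc2c(N)ncnc21` carries the change (hydrogen in place of oxolan-3-yl on a nitrogen on an aromatic ring). Going by the values given here, no measured step removes this group entirely, so the step from compound 1 to compound 2 bears on it only by showing that the amine substituent is felt; the direction of its complete removal is not settled by it. The author expects compound 3 to move further toward weaker inhibition, by a step of a 2.6-fold higher number from compound 2 to compound 3 (0.42 log units; beyond the scatter). Compound 3 is therefore estimated at 30000 nM in this assay, within a range from 8000 nM to 100000 nM.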

Compound 3, inhibition constant: 3020 nM
Compound 3: middle estimate off by 9.9-fold (1.00 log units), on the high side; measured number outside the range, below it.
By their numbers in this assay, from the lowest: compound 1; then compound 3; then compound 2.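

In this assay, removing the oxolan-3-yl group does not move compound 3 toward weaker inhibition, as there is a 3.8-fold lower number from compound 2 to compound 3 (0.58 log units; beyond the scatter) on going to the plain amino group. Against the cyclobutyl group the same kind of change runs the other way, with a 2.1-fold higher number from compound 1 to compound 3 (0.32 log units; beyond the scatter), so the two substituted compounds fall on opposite sides of the unsubstituted amine and the outcome at this nitrogen depends on which group is attached, not merely on whether one is present. Nothing measured here explains why these two groups part in this way.

The compounds shown do not tell where a cyclopentyl ring, an oxan-4-yl ring or an open chain such as propyl on this nitrogen would fall relative to compound 3. They also leave open whether this order of the three groups holds when the shared core is changed elsewhere.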